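The source may report more compounds than this note shows. Statements on the series, on what has been measured and on what is new or still open speak of the compounds shown alone.

Measured so far:
Compound 1 `O=C(C1=C(O)C(=O)N(CCCn2ccnc2)C1c1ccc(Br)cc1)c1ccccc1` — in a functional assay on U2OS cells (Homo sapiens) for antiproliferative activity, read by MTT assay, with a stated time of 72 h (on this read-out lower numbers stand for stronger inhibition and higher numbers for weaker inhibition), compound 1 is reported as "not active" (no number reported).
Compound 2 `CCCCOC1=C(C(=O)c2ccccc2)C(c2ccc(Br)cc2)N(CCCn2ccnc2)C1=O` — in this assay compound 2 gives 32400 nM.
Compound 3 `O=C(C1=C(OC2CCCCC2)C(=O)N(CCCn2ccnc2)C1c1ccc(Br)cc1)c1ccccc1` — in this assay compound 3 gives 22400 nM.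

Compound 2 holds the highest of the two reported numbers; compound 3 is nearest, with a 1.4-fold lower number from compound 2 to compound 3 (0.16 log units; within the scatter). Compound 1 carries no number at all.

Compound 4 `Cc1ccc(NC2=C(C(=O)c3ccccc3)C(c3ccc(Br)cc3)N(CCCn3ccnc3)C2=O)cc1` differs from compound 2 by (4-methylphenyl)amino in place of butoxy on a double-bonded ring carbon. For the measured compounds named here, the single measured step, butyl to cyclohexyl on the same oxygen, bears only loosely on this change, and no measured step replaces butoxy with an amino group. The expectation in this assay is accordingly no step beyond the scatter, held with wide uncertainty, a 1.3-fold lower number from compound 2 to compound 4 (0.11 log units; within the scatter). Compound 4 is estimated at 25000 nM, within a range of 8000 nM to 80000 nM.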

Compound 4, half-maximal inhibitory concentration: 24100 nM
Estimate against measurement, compound 4: 1.0-fold (0.02 log units) above; the range from low to high includes it.
By their numbers in this assay, from the lowest: compounds 3, 4 and 2 (each within the scatter of the next).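

In this assay, for the compounds shown here, (4-methylphenyl)amino is the first group at this double-bonded ring carbon joined through nitrogen rather than oxygen, yet the number stays within the scatter against both butoxy (a 1.3-fold lower number from compound 2 to compound 4 (0.13 log units; within the scatter)) and cyclohexyloxy (a 1.1-fold higher number from compound 3 to compound 4 (0.03 log units; within the scatter)). The position thus accepts a nitrogen link, an aromatic ring and a hydrogen-bond donor together with no step beyond the scatter. Nothing available explains this flat response.

On these data alone, whether piperidine, or a phenylamino group bearing a carboxylic acid, at this carbon would give a step beyond the scatter stays open.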